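Swapping Chloro for Bromo on a Shared Urea Core

A few compounds are considered here, and "the series" means these few. Any claim that something is new, unique, unknown or untested is made for them only; others in the source may bear on it.

Compound 3 `C[C@H](NC(=O)Nc1cccc(Cl)c1)c1ccccc1` gives 99% in an ADME assay on the whole organism with Oryza sativa as the target, tested at 1 uM (a lower number here means a stronger effect, a higher number a weaker effect of the compound at the concentration tested), the highest of the three numbers shown so far, although compound 1 `CCc1cccc(NC(=O)N[C@@H](C)c2ccccc2)c1` with 94% and compound 2 `C[C@H](NC(=O)Nc1cccc(C(F)(F)F)c1)c1ccccc1` with 93% both lie within the scatter of it. Compound 4 `C[C@H](NC(=O)Nc1cccc(Br)c1)c1ccccc1` differs from compound 3 in one place: bromo in place of chloro on an aromatic carbon. For the measured compounds named here, three measured steps concern this same position on the shared core: a number 1 percentage points lower from compound 1 to compound 2 (within the scatter), a number 5 percentage points higher from compound 1 to compound 3 (within the scatter) and a number 6 percentage points higher from compound 2 to compound 3 (within the scatter), every one within the scatter, so exchanging the group at this carbon has so far left this assay essentially unmoved. The exchange of one halogen for another is therefore expected to bring no step beyond the scatter, an expected a number 2 percentage points lower from compound 3 to compound 4 (within the scatter). Compound 4 is estimated at 97%, in the range 89% to 103%.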

Compound 4, a percentage reported as activity, at one concentration (the size of the read-out at that concentration, not a potency): 100%
Compound 4: middle estimate off by 3 percentage points, on the low side; measured number inside the range.
By their numbers in this assay, from the lowest: compounds 2, 1, 3 and 4 (each within the scatter of the next).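

Bromo reads like the other three groups at this aromatic carbon: a number 1 percentage points higher from compound 3 to compound 4 (within the scatter) against chloro, a number 7 percentage points higher from compound 2 to compound 4 (within the scatter) against trifluoromethyl and a number 6 percentage points higher from compound 1 to compound 4 (within the scatter) against ethyl in this assay with no step beyond the scatter. The flat picture now covers two halogens as well as ethyl and trifluoromethyl, so a change between halogens leaves the read-out as unmoved as the other exchanges do. Nothing available explains why the read-out stays flat. Going by these compounds, whether an amine, a carboxylic acid or a longer chain at this carbon would shift this assay stays open. Changes elsewhere on the shared core also remain unknown.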